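The source may report more compounds than this note shows. Statements on the series, on what has been measured and on what is new or still open speak of the compounds shown alone.

Compound 1 `CCOC(=O)c1csc(CO/N=C(\C)c2ccc(Sc3cc(F)cc(C4CCOCC4)c3)cc2)n1`: 150 nM
Compound 2 `C/C(=N\OCC(O)CO)c1ccc(S(=O)(=O)c2cccc(C3CCOCC3)c2)cc1`: 160 nM
Compound 3 `CO[C@]1(c2cc(F)cc(Sc3ccc(/C(C)=N/OCC#N)cc3)c2)CCO[C@@H](C)C1`: 40 nM

Of the compounds shown here, three sharing the same aryl oxime ether core have been measured in a functional assay (blood) for inhibition, with Homo sapiens as the target; a higher number here means a weaker inhibitor, a lower number a stronger inhibitor. Compound 1 gives 150 nM, the second highest of the three numbers. Its nearest neighbour is compound 2 with 160 nM, a gap that lies within the usual scatter, so the two cannot be told apart. Compound 3, at 40 nM, stands furthest from compound 1 and the gap between them is beyond the scatter.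

Compound 4 `COC(=O)C(C)(C)CO/N=C(\C)c1ccc(Sc2cc(F)cc(C3CCOCC3)c2)cc1` has not yet been measured. It differs from compound 1 in one place: 1-(methoxycarbonyl)-1-methylethyl in place of 4-(ethoxycarbonyl)-1,3-thiazol-2-yl on a saturated chain carbon bound to an oxygen on an unsaturated carbon. For the measured compounds named here, no pair of measured compounds shows this change, so there is no measured step to lean on; the three measured values only show that variations of the chain on the oxime oxygen have so far moved the number by modest amounts.

Compound 4 is therefore expected to sit close to compound 1 in this assay, with a step of a 1.2-fold higher number from compound 1 to compound 4 (0.08 log units; within the scatter) that is not expected to exceed the scatter. The estimate for compound 4 is 180 nM, within a range from 60 nM to 550 nM.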

Compound 4, half-maximal inhibitory concentration: 420 nM
For compound 4 the middle estimate is 2.3-fold (0.37 log units) below the measured one; measured number inside the range.
By their numbers in this assay, from the lowest: compound 3; then compounds 1 and 2 (each within the scatter of the next); then compound 4.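

In this assay the step at this position is now measured: 1-(methoxycarbonyl)-1-methylethyl in place of 4-(ethoxycarbonyl)-1,3-thiazol-2-yl on a saturated chain carbon bound to an oxygen on an unsaturated carbon gives a 2.8-fold higher number from compound 1 to compound 4 (0.45 log units; beyond the scatter). The step is modest, but it shows that this position is not indifferent to the group it carries. Both groups hold an ester, so an ester on this chain does not by itself keep the number of compound 1, and no measurement at hand accounts for the step.

This single step cannot separate the loss of the five-membered aromatic ring from the change in the chain around the ester. The compounds shown also leave open how a carboxylic acid or a primary amide in place of the ester would read at this position.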